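Chloro to amino on the shared core

The source may report more compounds than this note shows. Statements on the series, on what has been measured and on what is new or still open speak of the compounds shown alone.

Compound 1 `OCCOCn1c(Cl)nc2cc(Cl)c(Cl)cc21` carries two chloro groups on the six-membered part of the shared core and a third chloro on the five-membered ring. In a functional assay on KB cells (Homo sapiens) for inhibition (a higher number here means a weaker inhibitor, a lower number a stronger inhibitor), compound 1 reaches only the limit of > 320000 nM, so no number is known for it. Compound 2 `OCCOCn1c(Cl)nc2c(Cl)c(Cl)ccc21` moves the two chloro groups to the other side of the fused system. In this assay compound 2 likewise stops at a limit, > 100000 nM. Where compound 1 stands on the figures so far is therefore a boundary only: both values shown are limits (the limit of > 100000 nM in this assay, at which 1 of the 2 values shown sits; (the limit of > 320000 nM in this assay, at which 1 of the 2 values shown sits)), and no step between measured compounds can be sized.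

Compound 3 `Nc1nc2cc(Cl)c(Cl)cc2n1COCCO` differs from compound 1 in one place: amino in place of chloro on an aromatic carbon, in words amino in place of chloro on an aromatic carbon. Among the measured compounds shown here, no measured step in the set covers such a change, and the two values at hand are limits; nothing among them points in either direction. In this assay the expected step is an at least 1.0-fold lower number from compound 1 to compound 3 (0.02 log units; that floor lies within the scatter), none beyond the scatter. Compound 3 is expected to give 300000 nM in this assay, within 50000 nM to 1000000 nM, most probably reported again as a limit rather than a number.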

Compound 3, half-maximal inhibitory concentration: > 100000 nM
Compound 3: only a limit was reported (the forecaster's own chance of this, stated with the estimate: 85%); the middle value lies beyond the limit too.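

Among the compounds shown here, compound 1 and compound 3 both stop at limits in this assay; no step for amino in place of chloro on an aromatic carbon can be read between them. The compounds shown leave open what number any of them would reach, and whether this change moves inhibition in either direction.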